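The source may report more compounds than this note shows. Statements on the series, on what has been measured and on what is new or still open speak of the compounds shown alone.

Three related compounds have been tested so far in an ADME assay on BJ cells (Homo sapiens) for cytotoxicity, with a stated time of 72 h; a lower number here means that less compound is needed, a higher number that more compound is needed for the effect. Compound 1 (`C=C[C@](C)(CCCC(C)C)CCc1ccc(O)cc1`) gives > 36600 nM as a limit of the assay, not a number. Compound 2 (`C=C[C@@](C)(/C=C/c1ccc(O)cc1)CCCO`) gives > 36600 nM as a limit too. Compound 3 (`C=C[C@@](C)(/C=C/c1ccc(O)c(/C=C/C#N)c1)CCC=C(C)C`) gives > 36600 nM as a limit as well, so it has no exact number of its own and stands level with the other two readings.

Compound 4 (`C=C[C@@](C)(/C=C/c1ccc(O)c(/C=C/C=C/c2ccccc2)c1)CCC=C(C)C`) keeps the core of compound 3 and alters one group (2-phenylethenyl in place of cyano on a double-bonded chain carbon bound to a double-bonded chain carbon). Here 2-phenylethenyl stands in place of cyano on a double-bonded chain carbon bound to a double-bonded chain carbon. Among the compounds with values here, no measured pair shows what a swap of this kind does in this assay, so any forecast has little to rest on. The expected change is small, possibly none beyond the scatter, and any shift should run toward a lower number because the limit of > 36600 nM in this assay, at which 3 of the 3 values shown sit, leaves no measured value to suggest otherwise. The estimated change is an at least 1.2-fold lower number from compound 3 to compound 4 (0.08 log units; that floor lies within the scatter) in this forecast. For compound 4 the estimated value is 30000 nM with an expected range from 12000 nM to 36600 nM in the same assay, and a reading that is again only a limit would be no surprise.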

Compound 4, half-maximal effective concentration: > 36600 nM
Compound 4 was reported as a limit (the forecaster's own chance of this, stated with the estimate: 70%); at least 1.2-fold (0.08 log units) between middle value and limit.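

Compound 4 gives > 36600 nM, which is a limit of the assay and not a number. Compound 3 also has only a limit, so no step can be read between compound 3 and compound 4. The compounds shown leave open what exact concentration any of them needs, and whether 2-phenylethenyl in place of cyano changes it at all.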